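Extending the chain on the triazole carbon of compound 1

The compounds below may be only part of what the source reports. "The series", "measured", "known", "first", "only" and "open" are said of these compounds alone.

Measured compounds:
- compound 1, `CCCCCCOc1ccc(-n2cnnc2)cc1`: 9.8 mg/kg
- compound 2, `CCCCCCOc1ccc(-n2cnnc2C)cc1`: 22.8 mg/kg
- compound 3, `CCCCCCOc1ccc(-n2cnnc2CC)cc1`: 13.2 mg/kg

All three were tested in a functional assay on the whole organism (strain C57B/6) with Mus musculus as the target, in the maximal electroshock model; a higher number here means that more compound is needed for the effect, a lower number that less compound is needed. On these numbers compound 1 has the lowest dose of the three; compound 3 sits close to it, within the scatter, while compound 2 lies beyond the scatter above it. The step of a 2.3-fold higher number from compound 1 to compound 2 (0.37 log units; beyond the scatter) is modest, and the step of a 1.3-fold higher number from compound 1 to compound 3 (0.13 log units; within the scatter) stays within the scatter, as does a 1.7-fold lower number from compound 2 to compound 3 (0.24 log units; within the scatter).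

Compound 4, `CCCCCCOc1ccc(-n2cnnc2CCCC)cc1`, differs from compound 1 in one place: butyl in place of hydrogen on an aromatic carbon. The two measured steps that bear on this change both put a chain on the same aromatic carbon, and they point in the same direction: a longer chain raised the dose slightly, with the shorter methyl giving the larger rise. Going by the values given here, a still longer butyl chain extends that series, but nothing measured shows how far it carries; with only two steps, no firm trend can be claimed, and compound 3 already pulls back toward compound 1.

The expectation is therefore a step of a 1.6-fold higher number from compound 1 to compound 4 (0.21 log units; within the scatter) that lies near the edge of the scatter, upward if anything. For compound 4 in this assay the expected value is 16 mg/kg, with a range from 7 mg/kg to 38 mg/kg.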

Compound 4, dose for half-maximal effect: 13.6 mg/kg
Beside the measured number, compound 4's estimate is 1.2-fold (0.07 log units) above it; measured number inside the range.
By their numbers in this assay, from the lowest: compounds 1, 3, 4 and 2 (each within the scatter of the next, the first and the last beyond it).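

In this assay, the butyl group on this aromatic carbon, between two ring nitrogen atoms, leaves the dose indistinguishable from that of the unsubstituted compound (a 1.4-fold higher number from compound 1 to compound 4 (0.14 log units; within the scatter)), so this position accepts a chain of this length without a change that can be read. The new compound also cannot be separated from the other two chain-bearing compounds (a 1.0-fold higher number from compound 3 to compound 4 (0.01 log units; within the scatter); a 1.7-fold lower number from compound 2 to compound 4 (0.22 log units; within the scatter)), which means the numbers show no trend with chain length across methyl, ethyl and butyl, and the only step among these four compounds that clears the scatter remains the one for methyl (a 2.3-fold higher number from compound 1 to compound 2 (0.37 log units; beyond the scatter)). No measurement shown offers an explanation for these numbers.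

As far as these compounds go, it remains open whether a longer chain such as octyl, a branched group such as isopropyl, or a ring such as phenyl on this carbon would keep the dose in the same range. An amine or a carboxylic acid at the end of the butyl chain is also untested territory in what is shown here, so the compounds shown say nothing about how such groups would behave at this position.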